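The source may report more compounds than this note shows. Statements on the series, on what has been measured and on what is new or still open speak of the compounds shown alone.

In a functional assay on ZR-75-1 cells (Homo sapiens) for inhibition, read by sulforhodamine B assay (a lower number here means a stronger inhibitor of growth, a higher number a weaker inhibitor of growth), compound 3 `Oc1cccc2[nH]c(-c3ccc(-c4ccc(-c5ccccc5)cc4)cc3)nc12` gives 35600 nM, the second highest of the three numbers, with compound 1 `c1ccc(-c2ccc(-c3ccc(-c4nc5ccccc5[nH]4)cc3)cc2)cc1` at 100000 nM and compound 2 `COc1cc(-c2ccc(-c3ccc(-c4nc5cc(C)ccc5[nH]4)cc3)cc2)cc(OC)c1OC` at 190 nM. Compound 4 `CN(C)c1ccc(-c2ccc(-c3ccc(-c4nc5c(O)cccc5[nH]4)cc3)cc2)cc1` has dimethylamino in place of hydrogen on an aromatic carbon, para to a large group: dimethylamino in place of hydrogen on an aromatic carbon. Going by the values given here, the only measured single-place step, a 2.8-fold lower number from compound 1 to compound 3 (0.45 log units; beyond the scatter), is modest and concerns the hydroxy, not the ring changed here, so it does not size this change. Among the compounds with values here, compound 2 at 190 nM is the only measured compound substituted on that ring, but it also differs elsewhere, so it is only a loose pointer. A large move to a lower number is expected, estimated as an 18-fold lower number from compound 3 to compound 4 (1.25 log units; beyond the scatter). Compound 4 is estimated at 2000 nM, with an expected range of 200 nM to 15000 nM.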

Compound 4, concentration for 50% growth inhibition: 4100 nM
Compound 4: middle estimate off by 2.1-fold (0.31 log units), on the low side; measured number inside the range.
By their numbers in this assay, from the lowest: compound 2; then compound 4; then compound 3; then compound 1.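

In this assay, dimethylamino in place of hydrogen on an aromatic carbon, para to a large group, gives an 8.7-fold lower number from compound 3 to compound 4 (0.94 log units; beyond the scatter). Going by these compounds alone, this is the first single-place reading at this position, and it shows that a substituent here can lower the number beyond the scatter. Nothing measured here accounts for the step.

From the compounds shown here alone, whether a primary amine or a morpholine at the same place would give a step of similar size remains open. So does whether dimethylamino would give this step on the core of compound 1, which lacks the hydroxy.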